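A few compounds are considered here, and "the series" means these few. Any claim that something is new, unique, unknown or untested is made for them only; others in the source may bear on it.

Compound 1 `CC(C)N(Cc1cccc(OCCCCCC(=O)O)c1)C(=O)c1ccccc1` carries an unsubstituted benzamide and was tested in an ADME assay on BJ cells (Homo sapiens) for cytotoxicity, read by CellTiter-Glo and resazurin assay, with a stated time of 72 h; a lower number here means that less compound is needed, a higher number that more compound is needed for the effect. In this assay compound 1 gives > 26000 nM, which is a limit of the assay rather than a number. Compound 2 `CC(C)N(Cc1cccc(OCCCCCC(=O)O)c1)C(=O)c1ccc(-c2ccsc2)cc1` carries thiophen-3-yl in place of hydrogen on an aromatic carbon, and in this assay compound 2 gives > 26000 nM, again only a limit. The step that the two limits leave unreadable from compound 1 to compound 2 therefore cannot be read. Compound 3 `CC(C)N(Cc1cccc(OCCCCCC(=O)O)c1)C(=O)c1ccc(-c2cccc(OCc3ccccc3)c2)cc1` extends the biaryl further, and in this assay compound 3 gives > 26000 nM, once more a limit. Compound 3 thus stands at the limit of > 26000 nM in this assay, at which 3 of the 3 values shown sit, together with every other value shown, and no number places it.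

Compound 4 `CCOc1cccc(-c2ccc(C(=O)N(Cc3cccc(OCCCCCC(=O)O)c3)C(C)C)cc2)c1` has not yet been measured. It differs from compound 3 by methyl in place of phenyl on a saturated chain carbon bound to an oxygen on an aromatic ring, which read one bond further out is benzyl to ethyl, or benzyloxy to ethoxy. No measured step bears on this change, since the only step shown is unreadable and every value is a limit. Because all three values sit at the limit of > 26000 nM in this assay, at which 3 of the 3 values shown sit, compound 4 is expected to show no change beyond the scatter. The expected step of a number no higher from compound 3 to compound 4 (the limit leaves the size open) rests on nothing more than that limit. Compound 4 is expected at about 26000 nM, within 13000 nM to 100000 nM, most probably reported again as a limit.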

Compound 4, half-maximal effective concentration: > 20800 nM
Compound 4: a limit, no number; the forecaster's own chance of this, stated with the estimate: 85%; the middle value lies beyond the limit too.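

In this assay compound 4 gives > 20800 nM, which is a limit of the assay and not a number. Among these compounds, compound 1, compound 2 and compound 3 also stand only at limits, so no step from any of them to compound 4 can be read. The compounds shown leave open at what concentration, if any, each reaches the half-maximal effect, and whether the groups that differ among them change it.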